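A few compounds are considered here, and "the series" means these few. Any claim that something is new, unique, unknown or untested is made for them only; others in the source may bear on it.

Compound 1 `COc1cc2c(Oc3ccc(NC(=O)c4nn(-c5ccccc5Br)c(=O)c5ccccc45)cc3F)ccnc2cc1OCCCN1CCN(C)CC1` gives 1680 nM in a functional assay on MDA-MB-231 cells (Homo sapiens) for cytotoxicity, read by MTT assay, with a stated time of 72 h; on this read-out higher numbers stand for weaker inhibition and lower numbers for stronger inhibition.
Compound 2 `COc1cc2c(Oc3ccc(NC(=O)c4nn(-c5ccc([N+](=O)[O-])cc5)c(=O)c5ccccc45)cc3F)ccnc2cc1OCCCN1CCN(C)CC1` gives 3490 nM in this assay.
Compound 3 `COc1cc2c(Oc3ccc(NC(=O)c4nn(-c5ccccc5Br)c(=O)c5ccccc45)cc3F)ccnc2cc1OCCCN1CCC(C)CC1` gives 1240 nM in this assay.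

Compound 4 `COc1cc2c(Oc3ccc(NC(=O)c4nn(-c5ccc([N+](=O)[O-])cc5)c(=O)c5ccccc45)cc3F)ccnc2cc1OCCCN1CCC(C)CC1` has not yet been measured. It shares its core with compound 3; how that core differs from the core of compound 1 is given by 4-methylpiperidin-1-yl in place of 4-methylpiperazin-1-yl on a saturated chain carbon, three bonds along the chain from an oxygen on an aromatic ring, a change that produced a 1.4-fold lower number from compound 1 to compound 3 (0.13 log units; within the scatter). The change from compound 3 to compound 4 is 4-nitrophenyl in place of 2-bromophenyl on an aromatic nitrogen. The same change has already been made once, from compound 1 to compound 2, as 4-nitrophenyl in place of 2-bromophenyl on an aromatic nitrogen, and it gave a 2.1-fold higher number from compound 1 to compound 2 (0.32 log units; beyond the scatter). The place of the change is the same in both pairs word for word, so it is taken as the same change carried over to a core that differs only as described. Compound 4 is therefore expected to give a higher number than its parent, by an estimated step of a 2.1-fold higher number from compound 3 to compound 4 (0.32 log units; beyond the scatter), resting on the earlier step of a 2.1-fold higher number from compound 1 to compound 2 (0.32 log units; beyond the scatter) and on that single pair alone, so the estimate is held loosely. Compound 4 is estimated at 2600 nM, with a range expected from 1500 nM to 4600 nM.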

Compound 4, half-maximal inhibitory concentration: 4010 nM
For compound 4 the middle estimate is 1.5-fold (0.19 log units) below the measured one; measured number inside the range.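

Putting 4-nitrophenyl in place of 2-bromophenyl on the aromatic nitrogen again gave a higher number in this assay, here a 3.2-fold higher number from compound 3 to compound 4 (0.51 log units; beyond the scatter), and the two steps for this change agree: the same change on two cores in this assay, a 2.1-fold higher number (0.32 log units; beyond the scatter) from compound 1 to compound 2 and a 3.2-fold higher number (0.51 log units; beyond the scatter) from compound 3 to compound 4, 1.6-fold (0.19 log units) apart, within the scatter of two such steps. Putting 4-methylpiperidin-1-yl in place of 4-methylpiperazin-1-yl on the chain left the number within the scatter on the second core as well, with a 1.1-fold higher number from compound 2 to compound 4 (0.06 log units; within the scatter), and these two steps also agree: the same change on two cores in this assay, a 1.4-fold lower number (0.13 log units; within the scatter) from compound 1 to compound 3 and a 1.1-fold higher number (0.06 log units; within the scatter) from compound 2 to compound 4, 1.6-fold (0.19 log units) apart, within the scatter of two such steps. The two changes therefore carried over between these cores without a detectable interaction in this assay, but this rests on a single set of compound 1, compound 2, compound 3 and compound 4, and it shows neither why the aryl change raises the number nor that it would do so on any other core.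

The compounds shown leave open whether the step follows the nitro group or the place of the substituent on the phenyl ring, a question that 4-bromophenyl or 2-nitrophenyl would address. They also leave open how a morpholin-4-yl group or a shorter chain would behave.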